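Swapping a Methoxyphenyl Tail for a Methylphenyl Tail

The source may report more compounds than this note shows. Statements on the series, on what has been measured and on what is new or still open speak of the compounds shown alone.

Measured compounds:
compound 1, `O=C1C(=O)N(CCOc2ccc(Oc3ccccc3)cc2)c2ccc(OC(F)(F)F)cc21`, 93%
compound 2, `COc1ccc(OCCN2C(=O)C(=O)c3cc(OC(F)(F)F)ccc32)cc1`, 89%

Compound 1 and compound 2 share the same core and differ only in the group sitting on an oxygen on an aromatic ring. In an assay on isolated protein for positive allosteric modulation of muscarinic acetylcholine receptor M5 (Homo sapiens) (a higher number here means a larger maximal response, a lower number a smaller maximal response), compound 1 gives 93% and compound 2 gives 89%. Compound 2 holds the lower of the two numbers, yet the step of a number 4 percentage points lower from compound 1 to compound 2 (within the scatter), so the two compounds cannot be told apart on this read-out. Compound 3 `Cc1cccc(OCCN2C(=O)C(=O)c3cc(OC(F)(F)F)ccc32)c1` has not been measured. It differs from compound 2 in one place: 3-methylphenyl in place of 4-methoxyphenyl on an oxygen on a saturated carbon. For the measured compounds named here, the only measured step that touches this region of the molecule is the one from compound 1 to compound 2, and it was small. Compound 3 is therefore expected to give 90% in this assay, with a range from 76% to 104%. The expected step of a number 1 percentage points higher from compound 2 to compound 3 (within the scatter) is estimated to stay within the scatter.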

Compound 3, largest response reached (Emax), in percent of the reference or control that the assay uses: 91%
Compound 3: middle estimate off by 1 percentage points, on the low side; low and high end bracket the measured number.
By their numbers in this assay, from the lowest: compounds 2, 3 and 1 (each within the scatter of the next).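

In this assay the change reads as a number 2 percentage points higher from compound 2 to compound 3 (within the scatter) and shows that this position, on an oxygen on a saturated carbon, tolerates a swap of the whole ring group, not only of what sits on its oxygen. The 4-methoxyphenyl brings a hydrogen-bond acceptor and the 3-methylphenyl brings none, yet the two compounds cannot be told apart on this read-out, so compound 3 keeps a large maximal response without that acceptor. Nothing available explains why the response stays so level across this swap. What remains open is whether this position needs an aromatic ring at all, since every group shown here carries one. An amine or a carboxylic acid in place of the 3-methylphenyl could show how far this tolerance extends.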